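The compounds below may be only part of what the source reports. "The series", "measured", "known", "first", "only" and "open" are said of these compounds alone.

Working notes on the series. In a functional assay on MCF7 cells (Homo sapiens) for inhibition, read by sulforhodamine B assay (a higher number here means a weaker inhibitor, a lower number a stronger inhibitor), compound 1 `Cc1ccc(NC2=CC(=O)c3c(nc4n3[C@H]3OC[C@@H](O)[C@H]3OC4)C2=O)cc1C` gives 4950 nM and compound 2 `COc1ccccc1NC1=CC(=O)c2c(nc3n2[C@H]2OC[C@@H](O)[C@H]2OC3)C1=O` gives 6580 nM as measured numbers. Compound 3 `O=C1C(NCc2ccccc2)=CC(=O)c2c1nc1n2[C@H]2OC[C@@H](O)[C@H]2OC1` gives > 8000 nM in this assay and this is a limit of the assay, not a number, so its true position is not known.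

The next step leads to compound 4 `CCOc1ccccc1NC1=CC(=O)c2c(nc3n2[C@H]2OC[C@@H](O)[C@H]2OC3)C1=O` with the change 2-ethoxyphenyl in place of benzyl on an amine nitrogen on the same amine nitrogen, 2-ethoxyphenyl in place of benzyl.

Two measured steps also replace a substituted phenyl group with benzyl at this place: an at least 1.6-fold higher number from compound 1 to compound 3 (0.20 log units; that floor lies within the scatter) and an at least 1.2-fold higher number from compound 2 to compound 3 (0.08 log units; that floor lies within the scatter) in this assay on the same core. Both rest on the limit of compound 3, so they give floors and not sizes. The step of a 1.3-fold higher number from compound 1 to compound 2 (0.12 log units; within the scatter) shows that two different phenyl groups at this place remain close.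

On these steps, no change beyond the scatter is expected, and any shift should run toward a lower number. The expected step is an at least 1.3-fold lower number from compound 3 to compound 4 (0.12 log units; that floor lies within the scatter) and it is only an estimate resting on a limit. Compound 4 is estimated at 6000 nM with an expected range of 3000 nM to 11000 nM in this assay and it may also return only a limit.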

Compound 4, half-maximal inhibitory concentration: > 4000 nM
Compound 4: a limit, no number; the forecaster's own chance of this, stated with the estimate: 25%; the middle value does not contradict the limit.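

In this assay compound 4 gives > 4000 nM, a limit of the assay and not a number, so its steps from compound 1, compound 2 and compound 3 cannot be read. The compounds shown leave open where compound 3 and compound 4 truly stand, and whether 2-ethoxyphenyl on the amine nitrogen differs from benzyl at all.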